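The source may report more compounds than this note shows. Statements on the series, on what has been measured and on what is new or still open speak of the compounds shown alone.

Compound 3 `O=C(O)c1cccc(Cc2c(-c3ccc(Cl)cc3)nn3cc(Cl)ccc23)n1` stands second highest of the three numbers in a functional assay on cells for antagonist activity at prostaglandin E2 receptor EP1 subtype (Rattus norvegicus), read by fluorescence and calcium flux, with a stated time of 60 s (on this read-out higher numbers stand for weaker inhibition and lower numbers for stronger inhibition), where compound 3 gives 1100 nM. Among the measured compounds shown here, compound 1 `O=C(O)c1cccc(Cc2c(-c3ccccc3)nn3ccccc23)n1` gives 2300 nM and compound 2 `O=C(O)c1cccc(Cc2c(-c3ccccc3)nn3cc(Br)ccc23)n1` gives 11 nM; the one single-place step measured is a 210-fold lower number from compound 1 to compound 2 (2.32 log units; beyond the scatter). Compound 4 `O=C(O)c1cccc(Cc2c(-c3ccsc3)nn3cc(Cl)ccc23)n1` differs from compound 3 by thiophen-3-yl in place of 4-chlorophenyl on an aromatic carbon. For the measured compounds named here, no measured step alters that group on its own, and compound 2 and compound 3 differ in two places, so the measured step bears on this change only indirectly. The account therefore expects compound 4 to shift by a 3.7-fold lower number from compound 3 to compound 4 (0.56 log units; beyond the scatter), with wide uncertainty in either direction. Compound 4 is estimated at 300 nM, within a range from 40 nM to 2000 nM.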

Compound 4, half-maximal inhibitory concentration: 110 nM
For compound 4 the middle estimate is 2.7-fold (0.44 log units) above the measured one; the range from low to high includes it.
By their numbers in this assay, from the lowest: compound 2; then compound 4; then compound 3; then compound 1.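

In this assay, replacing 4-chlorophenyl with thiophen-3-yl gives a 10-fold lower number from compound 3 to compound 4 (1.00 log units; beyond the scatter) and is the first single-place change shown at this carbon of the five-membered ring with two nitrogens. The number at this position therefore responds to the aromatic group it carries, and that group need not be a six-membered ring of carbon only. No measurement offered here accounts for this step.

From the compounds shown here alone, it remains open how thiophen-2-yl, a pyridine ring or a furan ring would fare at this position. Going by these compounds, whether thiophen-3-yl would give a similar step alongside bromo on the core also remains open.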